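The compounds below may be only part of what the source reports. "The series", "measured", "known", "first", "only" and "open" are said of these compounds alone.

Working notes on the series, measured in a functional assay on PC-9 cells (Homo sapiens) for antiproliferative activity, read by MTT assay; a higher number here means a weaker inhibitor, a lower number a stronger inhibitor:

Compound 1 `C#CCSc1nc(Sc2nc(C)c(C)s2)c(C#N)c(-c2cc(OC)c(OC)c(OC)c2)n1`: > 20000 nM
Compound 2 `C#CCSc1nc(Sc2nccs2)c(C#N)c(-c2ccc(Br)cc2)n1`: 12100 nM
Compound 3 `C=CC(=O)Nc1ccccc1CN(C(=O)Nc1cccc(C(F)(F)F)c1)C1CCN(C(C)CCC)CC1`: 5590 nM

The entry for compound 1 is a limit of the assay and not a number, so it cannot be placed exactly against the others.

Of the two numeric values, compound 2 has the higher at 12100 nM, which makes it the weaker inhibitor of that pair. Compound 3 is the nearest at 5590 nM, and the gap between them lies beyond the usual scatter.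

The next compound to be tested is compound 4 `C#CCSc1nc(Sc2nccs2)c(C#N)c(-c2ccc(C)cc2)n1`. It departs from compound 2 in one place, with methyl in place of bromo on an aromatic carbon, para to a large group (methyl in place of bromo on an aromatic carbon). The same difference, cut one bond further out, reads 4-bromophenyl to 4-methylphenyl.

Among the measured compounds shown here, no measured pair differs in one place, so the data give no direct guide to the size of this step. The expectation therefore starts from compound 2 at 12100 nM, with no clear direction and no shift beyond the scatter in this assay. The expected outcome is a 1.1-fold higher number from compound 2 to compound 4 (0.03 log units; within the scatter), a small step at most. For compound 4 the estimated value is 13000 nM, with an expected range of 6000 nM to 20000 nM.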

Compound 4, half-maximal inhibitory concentration: 1110 nM
Compound 4: middle estimate off by 12-fold (1.07 log units), on the high side, and the stated range ends above it.
By their numbers in this assay, from the lowest: compound 4; then compound 3; then compound 2. At a limit, above all of these: compound 1.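

In this assay, among the compounds shown here, methyl in place of bromo gives an 11-fold lower number from compound 2 to compound 4 (1.04 log units; beyond the scatter), the only step that can be read at a single place. The aromatic carbon para to a large group is therefore not a silent position for compound 2 and compound 4: exchanging one heavy atom for another, with no ring, hydrogen-bond donor, hydrogen-bond acceptor or net charge entering or leaving, is enough for a large step in favour of 4-methylphenyl over 4-bromophenyl. Nothing measured in the series gives a reason for the size of this step.

For the compounds shown here, with only two groups compared at this carbon, it remains open whether the step reflects something gained with methyl or something lost with bromo, and chloro, ethyl, an amine or a carboxylic acid at the same place would help to separate the two readings. On these data alone, it also remains open whether the same exchange gives a step of similar size on another core, or with other groups elsewhere on the shared core of compound 2 and compound 4.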